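The compounds below may be only part of what the source reports. "The series", "measured", "known", "first", "only" and "open" are said of these compounds alone.

In an ADME assay on microsomes from liver (Mus musculus) for metabolic stability, read by LC-MS, using NADPH (a higher number here means that the compound lasts longer, a lower number that the compound disappears faster), compound 2 `CCC(C)(C)C(=O)N(O)Cc1ccc(F)cc1` gives 0.402 h. For the measured compounds named here, compound 1 `CCC(C)(C)C(=O)N(O)Cc1ccc(F)c(F)c1F`, the only other compound measured, gives 0.232 h, which lies within the usual scatter of compound 2. The move to compound 3 `CCC(C)(C)C(=O)N(O)Cc1ccc(F)c(F)c1` is fluoro in place of hydrogen on an aromatic carbon. Going by the values given here, no measured step shows this change directly. Among the compounds with values here, the only guide is compound 1 at 0.232 h, so no shift beyond the scatter is expected in this assay. The expected step of a 1.3-fold lower number from compound 2 to compound 3 (0.13 log units; within the scatter) is small. For compound 3 the estimate is 0.3 h, with an expected range from 0.17 h to 0.55 h.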

Compound 3, half-life: 0.188 h
Compound 3: the middle estimate sits 1.6-fold (0.20 log units) above what was measured; low and high end bracket the measured number.
By their numbers in this assay, from the lowest: compounds 3, 1 and 2 (each within the scatter of the next, the first and the last beyond it).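

In this assay fluoro in place of hydrogen on an aromatic carbon, ortho to a fluoro group, gives a 2.1-fold lower number from compound 2 to compound 3 (0.33 log units; beyond the scatter) as a directly measured step of modest size. Hydrogen in place of fluoro on an aromatic carbon gives a 1.2-fold lower number from compound 1 to compound 3 (0.09 log units; within the scatter) and so leaves compound 1 and compound 3 within the scatter of each other. Nothing at hand gives a reason for either step.

Going by these compounds, whether a chloro group, a methoxy group or a nitrile on this aromatic carbon would give a step of similar size stays open. So does the outcome of an amine on the same carbon.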